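Nitro-to-fluoro change across two cores in an inhibition series

The compounds below may be only part of what the source reports. "The series", "measured", "known", "first", "only" and "open" are said of these compounds alone.

Measured compounds in a functional assay on the whole organism (strain Wistar) for inhibition, with Rattus norvegicus as the target, with stated times of 30 min and 3 h, at a dose of 20 mg/kg by the oral route; on this read-out higher numbers stand for more inhibition at the one dose given (going by the name of the read-out) and lower numbers for less inhibition:
- compound 1, `O=C1OC(c2ccc(Cl)cc2)=C/C1=C\c1ccc([N+](=O)[O-])cc1`: 36%
- compound 2, `O=C1OC(c2ccc(Cl)cc2)=C/C1=C\c1ccc(F)cc1`: 70.4%
- compound 3, `O=C1/C(=C/c2ccc([N+](=O)[O-])cc2)C=C(c2ccc(Cl)cc2)N1Cc1ccccc1`: 19.8%

Compound 1 and compound 2 share one core and differ only by fluoro in place of nitro on an aromatic carbon. In this assay that change gives a number 34.4 percentage points higher from compound 1 to compound 2 (beyond the scatter). Compound 3 sits on a different core; how its core differs from the core of compound 1 is not broken down here. In this assay compound 3 gives the lowest of the three numbers, and its distances to compound 1 and to compound 2 both lie beyond the scatter.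

Compound 4, `O=C1/C(=C/c2ccc(F)cc2)C=C(c2ccc(Cl)cc2)N1Cc1ccccc1`, is not yet measured. It stands to compound 3 as compound 2 stands to compound 1: the change is fluoro in place of nitro on an aromatic carbon, and the place of the change is described in the same words for both pairs, so it is the same change made on a second core. Among the compounds with values here, with only one measured instance of this change, the expectation for compound 4 rests on the step from compound 1 to compound 2 alone, and it is not known whether the second core carries it to the same extent.

On that basis compound 4 is expected to give a step of a number 30.2 percentage points higher from compound 3 to compound 4 (beyond the scatter) in this assay, of the same kind as the earlier one because of a number 34.4 percentage points higher from compound 1 to compound 2 (beyond the scatter). The estimate for compound 4 is 50%, with a range from 30% to 68%.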

Compound 4, a percentage reported as inhibition, in the whole organism at one dose (the size of the read-out at that dose, not a potency): 89.5%
Compound 4: middle estimate off by 39.5 percentage points, on the low side; measured number above the stated range.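

In this assay, fluoro in place of nitro on the second core gives a number 69.7 percentage points higher from compound 3 to compound 4 (beyond the scatter), so the direction of the change seen on the core of compound 1 carries over to the core of compound 3. The size of the step does not carry over, and the two steps differ: the same change on two cores in this assay, a number 34.4 percentage points higher (beyond the scatter) from compound 1 to compound 2 and a number 69.7 percentage points higher (beyond the scatter) from compound 3 to compound 4, 35.3 percentage points apart, beyond the scatter of two such steps. Within the data shown here, this means that, for these two cores, a step measured on one indicates the direction on the other but not its size; with only two pairs, it does not show which feature of the cores sets the gap, nor how the change would behave on a further core.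

Among the compounds shown, this place on the aromatic ring holds only nitro or fluoro, so it remains open how an amine, a carboxylic acid or a methoxy group there would read on either core, and whether such groups would also give steps of different size on the two cores. Also open, going by these compounds, is whether the gap between the steps would persist at other oral doses, since each compound has a reading at only one dose.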